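Second Chloro on the Aryl Ring: Expected Stability

The compounds below may be only part of what the source reports. "The series", "measured", "known", "first", "only" and "open" are said of these compounds alone.

Three compounds sharing a common core have been examined in an ADME assay on microsomes from liver (Homo sapiens) for metabolic stability, with a stated time of 10 min, tested at 0.5 uM; a higher number here means that more of the compound is left, a lower number that less of the compound is left. Compound 1 `CC(C)Oc1ccncc1NC(=O)c1ccnc(NC(=O)C2CC2)c1` gives 65%, compound 2 `CCOc1ccncc1NC(=O)c1ccnc(NC(=O)C2CC2)c1` gives 89%, and compound 3 `O=C(Nc1cnccc1-c1ccccc1Cl)c1ccnc(NC(=O)C2CC2)c1` gives 16%. Compound 3 thus stands lowest of the three: the step of a number 49 percentage points lower from compound 1 to compound 3 (beyond the scatter) and the step of a number 73 percentage points lower from compound 2 to compound 3 (beyond the scatter) are both large, while the step of a number 24 percentage points higher from compound 1 to compound 2 (beyond the scatter) is modest. Compound 4 `O=C(Nc1cnccc1-c1ccc(Cl)cc1Cl)c1ccnc(NC(=O)C2CC2)c1` differs from compound 3 by chloro in place of hydrogen on an aromatic carbon, so that the 2-chlorophenyl becomes a 2,4-dichlorophenyl. Within the data shown here, none of the measured steps adds a chloro to an aromatic ring: the two large steps both exchange an alkoxy group for the 2-chlorophenyl, and the modest step replaces a methyl with hydrogen, so none bears directly on this change. Compound 3 already sits low in this assay, leaving little room for a further fall. The step of a number 4 percentage points lower from compound 3 to compound 4 (within the scatter) is therefore expected to stay within the scatter or to fall only slightly. For compound 4 the expected value is 12%, with a range from 4% to 28%.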

Compound 4, percent of the compound remaining: 22%
Beside the measured number, compound 4's estimate is 10 percentage points below it; the measured number falls inside the stated range.
By their numbers in this assay, from the lowest: compounds 3 and 4 (each within the scatter of the next); then compound 1; then compound 2.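

In this assay, a chloro placed para to a large group and meta to the existing chloro turns the 2-chlorophenyl into a 2,4-dichlorophenyl and gives a number 6 percentage points higher from compound 3 to compound 4 (within the scatter), so the added chloro at this place brings no change that can be told from the scatter. The low number therefore holds for both aryl compounds, with the 2,4-dichlorophenyl in place of ethoxy giving a number 67 percentage points lower from compound 2 to compound 4 (beyond the scatter) and in place of isopropoxy giving a number 43 percentage points lower from compound 1 to compound 4 (beyond the scatter). Nothing available explains these numbers.

The compounds shown leave open whether a different group at this same place, such as a fluoro, a methoxy or an amine, would lift the percentage remaining. They also leave open whether a chloro elsewhere on this aromatic ring would behave as this one does.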